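Microsomal stability notes: cyclohexyl acid to bridged bicyclic acid

A few compounds are considered here, and "the series" means these few. Any claim that something is new, unique, unknown or untested is made for them only; others in the source may bear on it.

The series shares a core carrying a piperidine amide; the compounds differ only in the acid-bearing group on the carbonyl carbon. Compound 1 `CCC[C@]1(C(=O)N2CC[C@](c3ccc(C(F)(C(F)(F)F)C(F)(F)F)cc3)(S(=O)(=O)c3ccc(F)cc3)C2)CC[C@H](C(=O)O)CC1` has "not determined" (no result reported) in an ADME assay on microsomes from liver (Mus musculus) for metabolic stability, with a stated time of 10 min; a lower number here means that less of the compound is left, a higher number that more of the compound is left. Compound 3 `O=C(O)C12CCC(C(=O)N3CC[C@](c4ccc(C(F)(C(F)(F)F)C(F)(F)F)cc4)(S(=O)(=O)c4ccc(F)cc4)C3)(CC1)C2` likewise has "not determined" (no result reported) in this assay. Compound 2 `CO[C@]1(C(=O)N2CC[C@](c3ccc(C(F)(C(F)(F)F)C(F)(F)F)cc3)(S(=O)(=O)c3ccc(F)cc3)C2)CC[C@H](C(=O)O)CC1` carries a methoxy in place of the propyl of compound 1. In this assay compound 2 gives 95%, so most of that compound remains. Compound 4 `O=C(O)C12CCC(C(=O)N3CC[C@](c4ccc(C(F)(C(F)(F)F)C(F)(F)F)cc4)(S(=O)(=O)c4ccc(F)cc4)C3)(CC1)CC2` is not yet measured. Relative to compound 1 the change is a group of 11 heavy atoms (9 carbon, 2 oxygen; 2 six-membered non-aromatic rings of carbon only) in place of a group of 12 heavy atoms (10 carbon, 2 oxygen; one six-membered non-aromatic ring of carbon only), on a carbonyl carbon. Among the compounds with values here, no measured step covers this change, and compound 1 itself has no number, so the expected step is taken as none beyond the scatter, anchored on compound 2. Compound 4 is therefore expected to give 85% in this assay, estimated within 60% to 100%.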

Compound 4, percent of the compound remaining: 73%
For compound 4 the middle estimate is 12 percentage points above the measured one; low and high end bracket the measured number.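

At this carbonyl carbon, the group carried does matter in this assay: a number 22 percentage points lower from compound 2 to compound 4 (beyond the scatter), with a group of 2 six-membered non-aromatic rings of carbon only replacing one with a single such ring. Even so, compound 4 at 73% retains most of the compound. Nothing available accounts for this step.

Compound 1 and compound 3 carry no single number, so their groups cannot be compared with those of compound 2 or compound 4. Going by these compounds, how an ethyl group in place of the methoxy of compound 2, or a primary amide in place of its carboxylic acid, would fare remains open.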